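A Phenyl Replaces Carbamoylmethyl on the Ring Nitrogen

The source may report more compounds than this note shows. Statements on the series, on what has been measured and on what is new or still open speak of the compounds shown alone.

Compound 1 `CCn1nnc2c(C(N)=O)cccc2c1=O`: 325000 nM
Compound 2 `NC(=O)Cn1nnc2c(C(N)=O)cccc2c1=O`: > 500000 nM
Compound 3 `NC(=O)c1cccc2c(=O)n(-c3ccccc3)nnc12`: not yet measured

Of the compounds shown here, two have been measured in a functional assay on TLX-5 cells (Mus musculus) for cytotoxicity; a higher number here means a weaker inhibitor, a lower number a stronger inhibitor. Compound 1 gives 325000 nM in this assay. For compound 2 the assay reports only its limit, > 500000 nM, so no number is known for it. The step of an at least 1.5-fold higher number from compound 1 to compound 2 (0.18 log units; that floor lies within the scatter) therefore rests on a limit (the limit of > 500000 nM in this assay, at which 1 of the 2 values shown sits). Compound 3 differs from compound 2 by phenyl in place of carbamoylmethyl on an aromatic nitrogen. For the measured compounds named here, no measured step covers this exchange; the only step at hand, which put carbamoyl in place of methyl on the chain, raised the number, and it ended in a limit. Removing the carbamoylmethyl might bring the number back toward where compound 1 stands, but this rests on one step. Compound 3 is thus expected to show the step of an at least 1.6-fold lower number from compound 2 to compound 3 (0.22 log units; that floor lies within the scatter) in this assay. The estimated value of compound 3 is 300000 nM, in the range 100000 nM to 700000 nM.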

Compound 3, half-maximal inhibitory concentration: > 500000 nM
Compound 3: no number, only a limit; the forecaster's own chance of this, stated with the estimate: 40%; at least 1.6-fold (0.22 log units) between middle value and limit.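

In this assay compound 3 also ends in a limit, > 500000 nM, so a phenyl on this aromatic nitrogen gives no readable number, just as the carbamoylmethyl of compound 2 did. Set against the ethyl group, the exchange gives an at least 1.5-fold higher number from compound 1 to compound 3 (0.18 log units; that floor lies within the scatter), and that floor alone does not separate the phenyl from the ethyl. The steps that join two limits cannot be read, and the series now gathers at one limit of the assay: the limit of > 500000 nM in this assay, at which 2 of the 3 values shown sit.

The compounds shown leave open how far compound 2 and compound 3 truly lie from compound 1, and whether any group on this nitrogen can lower the number at all. A methyl group, a longer chain ending in an amine, or a chain carrying a carboxylic acid would test this position further.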